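This account rests on a few compounds, and the source may have more. Where it says the series, first, only, none or still open, it means among the compounds named here.

Results in a functional assay on A549 cells (Homo sapiens) for antiproliferative activity, read by MTT assay, with a stated time of 48 h; a higher number here means a weaker inhibitor, a lower number a stronger inhibitor:
- Compound 1 `COc1ccc(C(=O)Nc2ccc3ncc(-c4cnn(C)c4)cc3n2)cc1`: 6400 nM
- Compound 2 `CC(=O)Nc1nccc2ncc(-c3cnn(C)c3)cc12`: > 50000 nM, a limit and not a number
- Compound 3 `COc1ccc(C(=O)Nc2nccc3ncc(-c4cnn(C)c4)cc23)cc1`: > 50000 nM, a limit and not a number
- Compound 4 `CCNc1nccc2ncc(-c3cnn(C)c3)cc12`: not yet measured

Compound 2 stands at the limit of > 50000 nM in this assay, at which 2 of the 3 values shown sit. It therefore offers a limit and no number from which to measure a step. Compound 4 differs from it as follows: ethyl in place of acetyl on a nitrogen on an aromatic ring. In words, ethyl takes the place of acetyl on a nitrogen on an aromatic ring, so acetamido becomes ethylamino.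

Going by the values given here, only one measured step starts from compound 2, and it changes the group on the carbonyl carbon: a step that the two limits leave unreadable from compound 2 to compound 3. It gives no size to carry over. Among the compounds with values here, compound 1 alone reaches a number, 6400 nM, and no single-place step links it to compound 2. Only a small move toward stronger inhibition in this assay is expected, and possibly none that can be read. The estimated change is an at least 1.2-fold lower number from compound 2 to compound 4 (0.09 log units; that floor lies within the scatter). Compound 4 is estimated at 40000 nM, with an expected range of 12000 nM to 100000 nM.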

Compound 4, half-maximal inhibitory concentration: 40700 nM
The estimate for compound 4 lay 1.0-fold (0.01 log units) below the measured number; the range from low to high includes it.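

On this nitrogen on an aromatic ring, removing the carbonyl by setting ethyl in place of acetyl yields a measurable value among the compounds sharing this core: in this assay compound 4 gives 40700 nM, whereas the earlier change on the carbonyl carbon gave a step that cannot be read. The new change reads as an at least 1.2-fold lower number from compound 2 to compound 4 (0.08 log units; that floor lies within the scatter), so it establishes a floor but no change beyond the scatter. The step has only a floor because compound 2 offers a limit and not a number: the limit of > 50000 nM in this assay, at which 2 of the 4 values shown sit.

The compounds shown leave open whether a longer chain such as butyl on this nitrogen would give a step beyond the scatter. They also leave open what an unsubstituted amine or a chain ending in a carboxylic acid would give there.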